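A Methyl for a Chloro on the Benzyl Ring

The compounds below may be only part of what the source reports. "The series", "measured", "known", "first", "only" and "open" are said of these compounds alone.

Three measured compounds share one core and differ only in the group on the saturated chain carbon bound to the sulfur. In a functional assay on KB cells (Homo sapiens) for inhibition (a lower number here means a stronger inhibitor, a higher number a weaker inhibitor), compound 1 `C#CCSc1nc2cc(Cl)c(Cl)cc2n1C1O[C@H](CO)[C@@H](O)[C@H]1O` gives 60000 nM. Compound 2 `N#CCSc1nc2cc(Cl)c(Cl)cc2n1C1O[C@H](CO)[C@@H](O)[C@H]1O` reaches the limit of this assay, > 100000 nM, and has no number of its own (the limit of > 100000 nM in this assay, at which 1 of the 3 values shown sits). Compound 3 `OC[C@H]1OC(n2c(SCc3cccc(Cl)c3)nc3cc(Cl)c(Cl)cc32)[C@H](O)[C@@H]1O` gives 19000 nM in this assay, the lowest of the two numbers in hand. The steps between them read an at least 1.6-fold higher number from compound 1 to compound 2 (0.22 log units; that floor lies within the scatter), a 3.2-fold lower number from compound 1 to compound 3 (0.50 log units; beyond the scatter) and an at least 5.2-fold lower number from compound 2 to compound 3 (0.72 log units; beyond the scatter). Compound 4 `Cc1cccc(CSc2nc3cc(Cl)c(Cl)cc3n2C2O[C@H](CO)[C@@H](O)[C@H]2O)c1` has not yet been measured; it differs from compound 3 by methyl in place of chloro on an aromatic carbon. Within the data shown here, none of the measured steps touches a substituent on that aromatic ring; each of them exchanges the whole group on the chain carbon, so they give no direct guide to this change. Among the measured compounds shown here, with no such step in hand, the chemist expects no change beyond the scatter and estimates the step as a 1.2-fold higher number from compound 3 to compound 4 (0.06 log units; within the scatter). For compound 4 the chemist therefore expects 22000 nM, with a range from 8000 nM to 60000 nM.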

Compound 4, half-maximal inhibitory concentration: 30000 nM
The estimate for compound 4 lay 1.4-fold (0.13 log units) below the measured number; measured number inside the range.
By their numbers in this assay, from the lowest: compounds 3, 4 and 1 (each within the scatter of the next, the first and the last beyond it). At a limit, above all of these: compound 2.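

Methyl in place of chloro on this aromatic carbon, the only step shown that changes the ring itself, gives a 1.6-fold higher number from compound 3 to compound 4 (0.20 log units; within the scatter) in this assay, so at this position the two groups cannot be told apart in this assay. Against the other groups on the chain carbon, the 3-methylphenyl group gives a 2.0-fold lower number from compound 1 to compound 4 (0.30 log units; within the scatter) and an at least 3.3-fold lower number from compound 2 to compound 4 (0.52 log units; beyond the scatter), so with methyl on the ring only the second of these steps lies beyond the scatter, whereas with chloro both do. That second step has a floor rather than a measured size, since compound 2 stands at a limit and not at a number: the limit of > 100000 nM in this assay, at which 1 of the 4 values shown sits.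

Only chloro and methyl are shown on this aromatic carbon, so it remains open whether the ring needs any group there at all. As far as these compounds go, how a methoxy group, an amine or a carboxylic acid at the same place would read in this assay also remains open.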